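A few compounds are considered here, and "the series" means these few. Any claim that something is new, unique, unknown or untested is made for them only; others in the source may bear on it.

Of the compounds shown here, three of one shared core have been measured in an in vitro functional assay on HEK285-7 cells for antagonist activity at prostaglandin D2 receptor 2 (Homo sapiens), read by BRET and beta-arrestin recruitment; on this read-out higher numbers stand for larger maximal responses and lower numbers for smaller maximal responses. Compound 1 `O=C(O)Cc1sc(Nc2ccc(Cl)cc2)nc1-c1ccc(F)cc1` carries a (4-chlorophenyl)amino group on the five-membered ring and a 4-fluorophenyl group beside it. In this assay compound 1 reaches > 70%, which is a limit of the assay and not a number. Compound 2 `O=C(O)Cc1sc(-c2ccccc2)nc1-c1ccc(F)cc1` has a phenyl in place of that (4-chlorophenyl)amino group. In this assay compound 2 reaches > 70%, again a limit and not a number. Compound 3 `O=C(O)Cc1sc(-c2ccccc2)nc1-c1ccc(-c2ccccc2)cc1` has a phenyl in place of the fluoro on the second aromatic ring. In this assay compound 3 reaches > 70%, also a limit.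

Because every value sits at the limit of > 70% in this assay, at which 3 of the 3 values shown sit, the measured steps cannot be sized: a step that the two limits leave unreadable from compound 1 to compound 2 and a step that the two limits leave unreadable from compound 2 to compound 3 both stay unreadable. Compound 2 therefore stands at the limit, with nothing to rank it against its neighbours.

Compound 4 `O=C(O)Cc1sc(Cc2ccccc2)nc1-c1ccc(F)cc1` is the next compound, not yet measured. The change from compound 2 is benzyl in place of phenyl on an aromatic carbon. The benzyl group enters on an aromatic carbon next to the ring nitrogen and the ring sulfur, where the phenyl of compound 2 stood. Among the measured compounds shown here, no measured step shows a readable change, so no step beyond the scatter is expected, and the move a step that the limit leaves unreadable from compound 2 to compound 4 is expected to leave compound 4 at the same limit. For compound 4 the expected efficacy is 82%, within 60% to 100%.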

Compound 4, largest response reached (reported as efficacy), in percent of the reference or control that the assay uses: 30%
For compound 4 the middle estimate is 52 percentage points above the measured one; measured number below the stated range.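

In this assay, the aromatic carbon next to the ring nitrogen and next to the ring sulfur now proves sensitive to the group it carries: benzyl in place of phenyl gives a number at least 40 percentage points lower from compound 2 to compound 4 (beyond the scatter). The change is small on paper, since both groups hold one six-membered aromatic ring of carbon only and benzyl adds a single carbon, yet the result is a number at least 40 percentage points lower from compound 1 to compound 4 (beyond the scatter) when benzyl takes the place of (4-chlorophenyl)amino instead. The other steps cannot be read, and compound 4 is the only compound here with a number rather than a limit, which makes these two steps the first that can be sized: the limit of > 70% in this assay, at which 3 of the 4 values shown sit.

From the compounds shown here alone, what remains open is how this position responds to other groups, for example whether a longer chain such as 2-phenylethyl lowers the number further, or whether a phenoxy group behaves like benzyl or like (4-chlorophenyl)amino. Going by these compounds, it is also open whether benzyl gives a similar step on the core of compound 3, where phenyl stands in place of the fluoro.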